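Swapping a Nitro Group for Bromo: Tolerability Outlook

This account rests on a few compounds, and the source may have more. Where it says the series, first, only, none or still open, it means among the compounds named here.

Of the compounds shown here, three have been tested in an ADME assay for cytotoxicity, read by propidium iodide staining; a higher number here means that more compound is tolerated, a lower number that less compound is tolerated. Compound 1 `O=c1c2ccccc2c(Cc2ccc(Cl)cc2)nn1-c1ccc([N+](=O)[O-])cc1` gives 96300 nM. Compound 2 `Cn1nc(Cc2ccc3ccccc3c2)c2ccccc2c1=O` gives 57200 nM, and compound 3 `CCCCn1nc(Cc2ccc(OC)c(OC)c2)c2ccccc2c1=O` gives 70300 nM. The number for compound 1 lies within the usual scatter of those for compound 2 and compound 3, so the three cannot be told apart on how much compound is tolerated. Compound 4 `O=c1c2ccccc2c(Cc2ccc(Cl)cc2)nn1-c1ccc(Br)cc1` has not yet been measured. It differs from compound 1 in one place: bromo in place of nitro on an aromatic carbon. Among the measured compounds shown here, no measured pair shows what this swap does in this assay, and the three numbers at hand give no hint of a shift beyond the scatter in either direction. The step of a 1.2-fold lower number from compound 1 to compound 4 (0.08 log units; within the scatter) is therefore expected to be small. Compound 4 is expected to give 80000 nM, within a range from 40000 nM to 160000 nM.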

Compound 4, half-maximal cytotoxic concentration: 91800 nM
The estimate for compound 4 lay 1.1-fold (0.06 log units) below the measured number, and the stated range covers the measured number.
By their numbers in this assay, from the lowest: compounds 2, 3, 4 and 1 (each within the scatter of the next).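

This pair is the only direct test of a change at this position. In this assay, bromo in place of nitro on the aromatic carbon gives a 1.0-fold lower number from compound 1 to compound 4 (0.02 log units; within the scatter), so the swap leaves no readable mark, even though a group of three heavy atoms with two hydrogen-bond acceptors gives way to a single bromine atom. Nothing measured here explains why the number holds.

Going by these compounds, whether an amine or a carboxylic acid at this position would also leave the number in place remains open. So does whether the same swap would read alike on another core.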